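From Acetyl to Benzoyl at the Assay Limit

The compounds below may be only part of what the source reports. "The series", "measured", "known", "first", "only" and "open" are said of these compounds alone.

Measured so far in an ADME assay on L929 cells (Mus musculus) for cytotoxicity, read by resazurin assay, with a stated time of 48 h; on this read-out lower numbers stand for higher toxicity in this test and higher numbers for lower toxicity in this test:
Compound 1 `CN(C)C(=O)CCCn1c2ccc([N+](=O)[O-])cc2c(=O)n1Cc1ccccc1`: > 256000 nM (a limit)
Compound 2 `CC(=O)n1c2ccc([N+](=O)[O-])cc2c(=O)n1Cc1ccccc1`: > 256000 nM (a limit)

Compound 2 gives > 256000 nM, which is a limit of the assay and not a number. Going by the values given here, the only other measured compound, compound 1, gives > 256000 nM, which is also a limit.

Compound 3 `O=C(c1ccccc1)n1c2ccc([N+](=O)[O-])cc2c(=O)n1Cc1ccccc1` keeps the shared core of compound 2 and differs in one place, with phenyl in place of methyl on a carbonyl carbon. The same difference can be read as acetyl to benzoyl.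

Among the compounds with values here, the only measured step bearing on this change is a step that the two limits leave unreadable from compound 1 to compound 2. It concerns a different group and offers no size to carry over. The firmest observation is the limit of > 256000 nM in this assay, at which 2 of the 2 values shown sit. On that basis, no step beyond the scatter is expected in this assay, and no direction is favoured. The expected change is a number no higher from compound 2 to compound 3 (the limit leaves the size open). Compound 3 is estimated at 256000 nM, with an expected range of 90000 nM to 512000 nM.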

Compound 3, concentration lethal to 50% of the cells: 146000 nM
Beside the measured number, compound 3's estimate is 1.8-fold (0.24 log units) above it; the measured number falls inside the stated range.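

On a carbonyl carbon whose other neighbour is an aromatic nitrogen, phenyl in place of methyl gives the only actual number among the three compounds shown: in this assay compound 3 gives 146000 nM. The values of compound 1 and compound 2 are limits and not numbers. The change reads as an at least 1.7-fold lower number from compound 2 to compound 3 (0.24 log units; that floor lies within the scatter), and the exchange of the whole group on the aromatic nitrogen reads as an at least 1.7-fold lower number from compound 1 to compound 3 (0.24 log units; that floor lies within the scatter); each is only a floor, so the true step may be larger, but the printed size alone does not clear the ordinary variation between repeated measurements. The step between compound 1 and compound 2 cannot be read, and the limit still holds most of the set: the limit of > 256000 nM in this assay, at which 2 of the 3 values shown sit.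

As far as these compounds go, it remains open whether any group at this position gives a step clearly beyond that variation. A longer chain on this carbonyl carbon, or an amine or a carboxylic acid on the phenyl ring, would show whether the lower number stays, grows or disappears.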